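Aryl exchange on the shared core: cytotoxicity outlook

The source may report more compounds than this note shows. Statements on the series, on what has been measured and on what is new or still open speak of the compounds shown alone.

Compound 1 `CCOc1cc(/C=C/C(=O)c2ccccc2NC(=O)NS(=O)(=O)c2ccc(C)cc2)ccc1O` gives 19.2 ug/mL in an ADME assay on the whole organism for cytotoxicity, with Artemia salina as the target, with a stated time of 24 h (a lower number here means that less compound is needed, a higher number that more compound is needed for the effect), and compound 2 `Cc1ccc(S(=O)(=O)NC(=O)Nc2ccccc2C(=O)/C=C/c2ccccc2[N+](=O)[O-])cc1` gives 40.1 ug/mL. Among the compounds with values here, compound 1 thus holds the lowest of the two numbers so far; its nearest neighbour is compound 2, reached by a 2.1-fold higher number from compound 1 to compound 2 (0.32 log units; beyond the scatter), a change made on a double-bonded chain carbon bound to a double-bonded chain carbon.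

Compound 3 `Cc1ccc(S(=O)(=O)NC(=O)Nc2ccccc2C(=O)/C=C/c2ccc(Cl)cc2Cl)cc1` has not yet been measured. It differs from compound 1 at the same place: 2,4-dichlorophenyl in place of 3-ethoxy-4-hydroxyphenyl on a double-bonded chain carbon bound to a double-bonded chain carbon

Within the data shown here, the only measured step that bears on this change is a 2.1-fold higher number from compound 1 to compound 2 (0.32 log units; beyond the scatter), in which the same 3-ethoxy-4-hydroxyphenyl was replaced by a differently substituted phenyl and the number rose modestly, beyond the scatter. Nothing else in the series separates the two replacements, so a step of similar size and direction is expected here. The step to compound 3 is estimated as a 1.7-fold higher number from compound 1 to compound 3 (0.22 log units; within the scatter). For compound 3 in this assay the expected value is 32 ug/mL, with a range from 15 ug/mL to 65 ug/mL.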

Compound 3, concentration for half-maximal effect: 8.34 ug/mL
Compound 3: middle estimate off by 3.8-fold (0.58 log units), on the high side, outside the stated range (below it).
By their numbers in this assay, from the lowest: compound 3; then compound 1; then compound 2.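

At this position, on a double-bonded chain carbon bound to a double-bonded chain carbon, the choice of replacing aryl group sets the direction of the step: in this assay the move to 2,4-dichlorophenyl gives a 2.3-fold lower number from compound 1 to compound 3 (0.36 log units; beyond the scatter) while the earlier move to 2-nitrophenyl gave a 2.1-fold higher number from compound 1 to compound 2 (0.32 log units; beyond the scatter) in the opposite direction. The two replacing groups also separate clearly from each other, with a 4.8-fold lower number from compound 2 to compound 3 (0.68 log units; beyond the scatter) as the largest step in the set, so a change away from 3-ethoxy-4-hydroxyphenyl cannot be read as a single effect of replacing that group. No measurement at hand explains why these replacements diverge.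

Still open, on these data alone, is whether the lower number in this assay needs both chlorine atoms of the 2,4-dichlorophenyl group, which a 4-chlorophenyl or an unsubstituted phenyl group at the same place would test. Also open, as far as these compounds go, is whether the trend extends beyond carbon-only aromatic rings, for example to a pyridine ring, since three compounds with one varied group support no broader pattern.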